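Swapping a dimethoxyphenyl for an aminophenyl on the sulfonamide

The source may hold more compounds than are shown below. What is called first, only, known or untested is meant among the compounds shown, and "the series" means these compounds.

Compound 3, `COc1ccc(S(=O)(=O)NCCN2CCC(CCC(=O)c3cc(Cl)c(N)cc3OC)CC2)c(OC)c1`, was tested in an assay on HEK293 cells for displacement of a labelled ligand from 5-hydroxytryptamine receptor 6 (Homo sapiens), with a stated time of 60 min, tested at 0.01 uM, in the presence of a further agent that is not named here (on this read-out higher numbers stand for a stronger effect at the one concentration tested and lower numbers for a weaker effect), and is reported there only as "not active" (no number reported), so no numeric value stands for it. The nearest guidance comes from two measured relatives. Compound 1, `COc1ccc(S(=O)(=O)NCCN2CCC(CCC(=O)c3cc(Cl)c(N)cc3OC)CC2)cc1OC`, gives 3% in this assay, while compound 2, `COc1cc(N)c(Cl)cc1C(=O)CCC1CCN(CCNS(=O)(=O)c2ccc(N)c(Br)c2)CC1`, gives 39%. Going by the values given here, the one measured step, a number 36 percentage points higher from compound 1 to compound 2 (beyond the scatter), shows that replacing a dimethoxyphenyl on the sulfonyl sulfur by an aminophenyl bearing a bromine raises the read-out well beyond the scatter.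

Compound 4, `COc1cc(N)c(Cl)cc1C(=O)CCC1CCN(CCNS(=O)(=O)c2ccc(N)cc2)CC1`, differs from compound 3 by 4-aminophenyl in place of 2,4-dimethoxyphenyl on a sulfonyl sulfur. This resembles the measured step in kind, although here no bromine accompanies the amine, so the change is only partly covered by the data, and compound 3 offers no number as a starting point. A rise in this assay is therefore expected rather than none, but of uncertain size. For compound 4 the expected read-out in this assay is 20%, with a range from 0% to 45%.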

Compound 4, a percentage reported as inhibition, at one concentration (the size of the read-out at that concentration, not a potency): 7%
Compound 4: the middle estimate sits 13 percentage points above what was measured; low and high end bracket the measured number.
By their numbers in this assay, from the lowest: compounds 1 and 4 (each within the scatter of the next); then compound 2.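

In this assay the new result separates the two parts of the earlier change: with the amine kept, a number 32 percentage points lower from compound 2 to compound 4 (beyond the scatter) when the bromo is removed, so among these compounds the higher read-out of compound 2 depends on the bromo and not on the amine alone. The amine without the bromo gives no clear gain over the dimethoxy compound, with a number 4 percentage points higher from compound 1 to compound 4 (within the scatter) on exchanging the groups on the sulfonyl sulfur, while the change from compound 3 cannot be read, since compound 3 has no number. Nothing measured here explains why the bromo matters.

Still open, going by these compounds, is whether an iodo or a methyl group in place of the bromo would keep the read-out. On these data alone, it is also open whether the bromo would have the same effect on a ring without the amine.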